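A few compounds are considered here, and "the series" means these few. Any claim that something is new, unique, unknown or untested is made for them only; others in the source may bear on it.

Measured so far:

Compound 1, `O=S(=O)(c1ccc(F)cc1)c1cn(C2CCNC2)c2ncccc12`, gives 8.5 nM.
Compound 2, `O=S(=O)(c1cccc(C(F)(F)F)c1)c1cn(C2CCNC2)c2ncccc12`, gives 1.3 nM.
Compound 3, `CN1CCC(n2cc(S(=O)(=O)c3ccccc3)c3cccnc32)C1`, gives 2.5 nM.

These three numbers come from an assay on HeLa cells for displacement of a labelled ligand from 5-hydroxytryptamine receptor 6 (Homo sapiens); a lower number here means a stronger inhibitor, a higher number a weaker inhibitor. Among them, compound 3 stands second highest. Its nearest neighbour is compound 2, whose number is lower but by a gap that lies within the usual scatter, so the two cannot be told apart. Compound 1 is the furthest away, with a higher number that lies beyond the scatter.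

Compound 4, `CN1CCC(n2cc(S(=O)(=O)c3cccc(Cl)c3)c3cccnc32)C1`, is not yet measured. It differs from compound 3 in one place: chloro in place of hydrogen on an aromatic carbon. In words, a chloro replaces a hydrogen on an aromatic carbon of the phenyl ring, meta to a large group, turning phenyl into 3-chlorophenyl.

Among the compounds with values here, no pair among the measured compounds differs in exactly this way, so no measured step can be used as a direct guide. Compound 2, which also carries a group on the phenyl ring, shows a low number, while compound 1 shows a higher one, but these two also differ elsewhere, so they only hint at the sizes that can occur.

For compound 4 in this assay, a number similar to or slightly lower than that of compound 3 is expected, with a step of a 1.6-fold lower number from compound 3 to compound 4 (0.19 log units; within the scatter). The estimate for compound 4 is 1.6 nM, expected to fall between 0.5 nM and 5 nM.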

Compound 4, inhibition constant: 1.5 nM
Beside the measured number, compound 4's estimate is 1.1-fold (0.03 log units) above it; measured number inside the range.
By their numbers in this assay, from the lowest: compounds 2, 4 and 3 (each within the scatter of the next); then compound 1.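

In this assay, within the data shown here, the change from phenyl to 3-chlorophenyl gives the first step that can be read at a single place, a 1.7-fold lower number from compound 3 to compound 4 (0.22 log units; within the scatter). The gap lies within the usual scatter, so adding this one chlorine atom to the phenyl ring produces no change that can be told apart from repeat measurement, something compounds 1 and 2 could not show because they differ from the others in more than one place. Nothing measured here bears on why the chloro leaves the number within the scatter.

A single step also says nothing about how other groups would fare at this place on the phenyl ring, such as a methoxy group, an amine or a carboxylic acid, or about a chloro placed elsewhere on that ring. It also leaves open whether the same chloro would give a similar small step on the core of compound 1, which has no methyl group on the nitrogen of its saturated ring.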